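The source may hold more compounds than are shown below. What is called first, only, known or untested is meant among the compounds shown, and "the series" means these compounds.

Compound 1 `C=C1C[C@]23C[C@@]1(O)CC[C@H]2c1cc(Br)c(O)c(C)c1[C@@H]3Cn1cc(-c2ccc(C)cc2)nn1` — in a functional assay on SW480 cells (Homo sapiens) for cytotoxicity, read by MTT assay, with a stated time of 4 days (on this read-out higher numbers stand for weaker inhibition and lower numbers for stronger inhibition), compound 1 gives > 20000 nM, which is a limit of the assay and not a number.
Compound 2 `C=C1C[C@]23C[C@@]1(O)CC[C@H]2c1cc(Br)c(O)c(C)c1[C@@H]3Cn1cc(-c2ccccn2)nn1` — in this assay compound 2 gives > 20000 nM, again only a limit.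
Compound 3 `Cc1c(O)ccc2c1[C@H](Cn1cc(-c3ccccc3)nn1)[C@@]13CC(=O)[C@@](C)(CC[C@@H]21)C3` — in this assay compound 3 gives > 20000 nM, also a limit.

Compound 2 therefore stands at the limit of > 20000 nM in this assay, at which 3 of the 3 values shown sit, where every value in this set sits. The change to compound 4 `C=C1C[C@]23C[C@@]1(O)CC[C@H]2c1cc(Br)c(O)c(C)c1[C@@H]3Cn1cc(-c2ccccc2)nn1` is phenyl in place of pyridin-2-yl on an aromatic carbon. Among the measured compounds shown here, the one measured step that touches this spot, a step that the two limits leave unreadable from compound 1 to compound 2, cannot be read in size, since both of its ends are limits, so no direction or size of change can be drawn from it. Compound 4 is thus expected to remain at the limit too, with an estimate of 30000 nM between 10000 nM and 100000 nM. This amounts to an expected step that the limit leaves unreadable from compound 2 to compound 4.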

Compound 4, half-maximal inhibitory concentration: > 20000 nM
Compound 4: no number, only a limit (the forecaster's own chance of this, stated with the estimate: 85%); the middle value is on the limit's open side.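

Compound 1, compound 2 and compound 4 each give only a limit, not a number, in this assay; the steps among them cannot be read. The compounds shown leave open how far any of these groups changes the cytotoxicity.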